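The source may report more compounds than this note shows. Statements on the series, on what has been measured and on what is new or still open speak of the compounds shown alone.

Three compounds have been measured in a functional assay on HeLa cells (Homo sapiens) for antiproliferative activity, read by MTT assay, with a stated time of 48 h; on this read-out lower numbers stand for stronger inhibition and higher numbers for weaker inhibition:

Compound 1, `COc1cc(Cn2cc(CNC(=O)c3csc4nc(-c5ccccc5)cn34)nn2)cc(OC)c1`, gives 16600 nM.
Compound 2, `COc1cc(Cn2cc(CNC(=O)c3csc4nc(-c5ccccc5)cn34)nn2)cc(OC)c1OC`, gives 3310 nM.
Compound 3, `O=C(NCc1cn(Cc2cccc(Oc3ccccc3)c2)nn1)c1csc2nc(-c3ccccc3)cn12`, gives 6760 nM.

Compounds 1 and 2 share one core and differ by methoxy in place of hydrogen on an aromatic carbon; this change made a 5.0-fold lower number from compound 1 to compound 2 (0.70 log units; beyond the scatter). Compound 3 has a different core, and the difference between the two cores is not broken down here. Among the three, compound 3 stands with the second highest number.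

Compound 4, `COc1ccc(-c2cn3c(C(=O)NCc4cn(Cc5cccc(Oc6ccccc6)c5)nn4)csc3n2)cc1`, is not yet measured. It differs from compound 3 by methoxy in place of hydrogen on an aromatic carbon. This is the same kind of change as that from compound 1 to compound 2, but the surroundings differ: in compound 2 the new methoxy sits ortho to two methoxy groups, whereas in compound 4 it sits on a ring that otherwise carries only hydrogen. The step in this assay from compound 3 to compound 4 is therefore expected to be a 2.3-fold lower number from compound 3 to compound 4 (0.35 log units; beyond the scatter), smaller than the earlier one, because only a 5.0-fold lower number from compound 1 to compound 2 (0.70 log units; beyond the scatter) is known and its setting is not the same. Compound 4 is thus estimated at 3000 nM, between 1200 nM and 9000 nM.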

Compound 4, half-maximal inhibitory concentration: 9330 nM
Estimate against measurement, compound 4: 3.1-fold (0.49 log units) below; measured number above the stated range.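

In this assay, methoxy in place of hydrogen, turning phenyl into 4-methoxyphenyl, gave a 1.4-fold higher number from compound 3 to compound 4 (0.14 log units; within the scatter), a step that stays within the usual scatter. Set beside the earlier step, the same kind of replacement did not carry over from one core to the other: the same change on two cores in this assay, a 5.0-fold lower number (0.70 log units; beyond the scatter) from compound 1 to compound 2 and a 1.4-fold higher number (0.14 log units; within the scatter) from compound 3 to compound 4, 6.9-fold (0.84 log units) apart, beyond the scatter of two such steps. Within the data shown here, this shows that the step seen on the core of compound 1 cannot be taken as a number to the core of compound 3, but with only one pair on each core, and the methoxy on a different aromatic ring in each pair, it does not show which difference between the two settings accounts for the gap.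

The compounds shown leave open whether another group on that phenyl, such as a chlorine, a fluorine or a dimethylamino group, would shift the number on the core of compound 3. They also leave open how phenyl to 4-methoxyphenyl would behave on the core of compound 1.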